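Replacing a Ring with an Open Amide Chain on a Shared Core

This account rests on a few compounds, and the source may have more. Where it says the series, first, only, none or still open, it means among the compounds named here.

Compound 3 `CC(C)C(/C=C1/CCNC1=O)c1ccc(-c2ccc3cccc(F)c3c2)[nH]c1=O` gives the lowest number of the three compounds measured in a functional assay on CHO cells for antagonist activity at prostaglandin E2 receptor EP3 subtype (Homo sapiens), read by cAMP accumulation (on this read-out lower numbers stand for stronger inhibition and higher numbers for weaker inhibition), with compound 3 at 8.1 nM. Its nearest neighbour is compound 2 `CC(C)C(c1ccc(-c2ccc3cccc(F)c3c2)[nH]c1=O)N1CCN/C1=N\C#N`, which gives 38 nM, and compound 1 `CC(C)C(c1ncco1)c1ccc(-c2ccc3cccc(F)c3c2)[nH]c1=O` gives 64 nM. The change to compound 4 `CC(C)C(CC(N)=O)c1ccc(-c2ccc3cccc(F)c3c2)[nH]c1=O` is a group of 4 heavy atoms (2 carbon, 1 nitrogen, 1 oxygen; no ring) in place of a group of 7 heavy atoms (5 carbon, 1 nitrogen, 1 oxygen; one five-membered non-aromatic ring with 1 hetero atom), on a saturated chain carbon bound to an aromatic carbon and a saturated chain carbon. Going by the values given here, two measured steps bear on this position: a 7.9-fold lower number from compound 1 to compound 3 (0.90 log units; beyond the scatter), and a 4.7-fold lower number from compound 2 to compound 3 (0.67 log units; beyond the scatter). Both show that the five-membered non-aromatic ring of compound 3 gave lower numbers than either of two other groups at the same place, while the step of a 1.7-fold lower number from compound 1 to compound 2 (0.23 log units; within the scatter) shows two quite different groups there giving numbers within the scatter of each other. Removing that ring in compound 4 is therefore expected to move the number upward by a modest amount in this assay, with compound 4 estimated at 40 nM, within a range from 12 nM to 130 nM. The expected step is a 4.9-fold higher number from compound 3 to compound 4 (0.69 log units; beyond the scatter).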

Compound 4, half-maximal inhibitory concentration: 53 nM
Estimate against measurement, compound 4: 1.3-fold (0.12 log units) below, within the range that was stated.
By their numbers in this assay, from the lowest: compound 3; then compounds 2, 4 and 1 (each within the scatter of the next).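

In this assay the ring of the leaving group matters at this place: putting carbamoylmethyl there gives a 6.5-fold higher number from compound 3 to compound 4 (0.82 log units; beyond the scatter) and gives up most of what that ring had shown. Carbamoylmethyl has the same counts of hydrogen-bond donors and acceptors as the group it replaces, so those counts alone do not go with the low number. The open chain also sits level with the two other groups, with a 1.4-fold higher number from compound 2 to compound 4 (0.14 log units; within the scatter) and a 1.2-fold lower number from compound 1 to compound 4 (0.08 log units; within the scatter), so among the four groups shown only the ring of compound 3 stands apart.

As far as these compounds go, whether the ring itself or its double bond carries the difference stays open, as does what a carboxylic acid or a longer chain ending in the amide would give at this place. Nothing measured here explains the gap.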